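The source may report more compounds than this note shows. Statements on the series, on what has been measured and on what is new or still open speak of the compounds shown alone.

Measured in a functional assay on HeLa cells (Homo sapiens) for inhibition, read by MTT assay, with a stated time of 48 h; a higher number here means a weaker inhibitor, a lower number a stronger inhibitor:
Compound 1 `Oc1ccc(C(c2c[nH]c3ccc(Br)cc23)c2c[nH]c3ccc(Br)cc23)cc1` gives 4000 nM
Compound 2 `COc1ccc(OC)c(C(c2c[nH]c3ccc(Br)cc23)c2c[nH]c3ccc(Br)cc23)c1` gives 5100 nM
Compound 3 `O=[N+]([O-])c1ccc(C(c2c[nH]c3ccc(Br)cc23)c2c[nH]c3ccc(Br)cc23)cc1` gives 1500 nM

Compound 3 holds the lowest number of the three. Compound 4 `CCCC(c1c[nH]c2ccc(Br)cc12)c1c[nH]c2ccc(Br)cc12` has propyl in place of 4-nitrophenyl on a saturated chain carbon bound to two aromatic carbons, a change counted as propyl in place of 4-nitrophenyl on a saturated chain carbon bound to two aromatic carbons. Among the compounds with values here, no measured compound carries a chain there, so the measured steps bear on this change only indirectly. Moving to 4-nitrophenyl gave a 2.7-fold lower number from compound 1 to compound 3 (0.43 log units; beyond the scatter) and a 3.4-fold lower number from compound 2 to compound 3 (0.53 log units; beyond the scatter), both modest, while a 1.3-fold higher number from compound 1 to compound 2 (0.11 log units; within the scatter) stays within the scatter. A modest rise is therefore expected in this assay on losing 4-nitrophenyl. The expected step is a 2.7-fold higher number from compound 3 to compound 4 (0.43 log units; beyond the scatter). Compound 4 is estimated at 4000 nM, with an expected range of 1300 nM to 12000 nM.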

Compound 4, half-maximal inhibitory concentration: 3900 nM
Estimate against measurement, compound 4: 1.0-fold (0.01 log units) above; measured number inside the range.
By their numbers in this assay, from the lowest: compound 3; then compounds 4, 1 and 2 (each within the scatter of the next).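

In this assay, replacing the phenyl group with propyl, which has no ring, leaves the number level, with a 1.0-fold lower number from compound 1 to compound 4 (0.01 log units; within the scatter) and a 1.3-fold lower number from compound 2 to compound 4 (0.12 log units; within the scatter) both within the scatter. The same propyl group lies clearly apart from 4-nitrophenyl, with a 2.6-fold higher number from compound 3 to compound 4 (0.41 log units; beyond the scatter) beyond the scatter, so among these four compounds only 4-nitrophenyl stands out on this saturated chain carbon, and a ring as such is not needed for the level of the others. No evidence accompanying these numbers accounts for this.

As far as these compounds go, whether a longer chain or an amine on the propyl chain would stay at that level remains open. So does whether a nitrile on the phenyl ring would match the nitro group of compound 3.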